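Imidazolylpropylguanidine series: halogen pattern on the phenyl group

The source may report more compounds than this note shows. Statements on the series, on what has been measured and on what is new or still open speak of the compounds shown alone.

Compound 3, `N=C(NCCCc1c[nH]cn1)NCCC(c1cc(F)cc(F)c1)c1ccccn1`, gives the highest number of the three measured compounds in a functional assay on cardiac atrium for agonist activity at histamine H2 receptor (Cavia porcellus) (on this read-out lower numbers stand for lower potency and higher numbers for higher potency (the scale is a negative logarithm)), at 8.05. Compound 1, `N=C(NCCCc1c[nH]cn1)NCCC(c1ccc(Cl)cc1)c1ccccn1`, gives 7.84 in this assay, and the step of a number 0.21 log units higher from compound 1 to compound 3 (within the scatter) lies within the scatter, so the two cannot be ranked against each other. Compound 2, `N=C(NCCCc1c[nH]cn1)NCCC(c1ccc(Br)cc1)c1ccccn1`, gives 7.48 in this assay; the step of a number 0.57 log units higher from compound 2 to compound 3 (beyond the scatter) is beyond the scatter, as is a number 0.36 log units lower from compound 1 to compound 2 (beyond the scatter).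

Compound 4, `N=C(NCCCc1c[nH]cn1)NCCC(c1ccc(Cl)c(Cl)c1)c1ccccn1`, differs from compound 3 by 3,4-dichlorophenyl in place of 3,5-difluorophenyl on a saturated chain carbon bound to an aromatic carbon and a saturated chain carbon. For the measured compounds named here, two measured steps bear on this position: a number 0.21 log units higher from compound 1 to compound 3 (within the scatter) and a number 0.57 log units higher from compound 2 to compound 3 (beyond the scatter), each replacing a single halogen on the phenyl group by the 3,5-difluorophenyl group. The step of a number 0.36 log units lower from compound 1 to compound 2 (beyond the scatter) shows that exchanging one halogen for another at the same position can move the number beyond the scatter. Going by the values given here, no measured pair exchanges fluorine for chlorine or alters a pattern of two halogens, so the direction for compound 4 is not fixed by the data. Compound 4 carries chlorine, as compound 1 does at 7.84. For compound 4 the expected step is a number 0.25 log units lower from compound 3 to compound 4 (within the scatter), within the scatter. Compound 4 is estimated at 7.8 in this assay, with a range from 7.3 to 8.3.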

Compound 4, negative logarithm of the half-maximal effective concentration: 8.19
Compound 4: the middle estimate sits 0.39 log units below what was measured; low and high end bracket the measured number.
By their numbers in this assay, from the lowest: compound 2; then compounds 1, 3 and 4 (each within the scatter of the next, the first and the last beyond it).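

In this assay the step of a number 0.35 log units higher from compound 1 to compound 4 (beyond the scatter) is the only one shown that adds a halogen to the phenyl group rather than exchanging one group for another, and it shows that a chloro in place of hydrogen on an aromatic carbon is accepted here with a change beyond the scatter. The step of a number 0.14 log units higher from compound 3 to compound 4 (within the scatter) leaves 3,4-dichlorophenyl and 3,5-difluorophenyl unranked against each other, while the step of a number 0.71 log units higher from compound 2 to compound 4 (beyond the scatter) is the largest shown in this series and separates the 3,4-dichlorophenyl group clearly from the 4-bromophenyl group; compound 3 goes against any general rule that two halogens outdo one, since the step of a number 0.21 log units higher from compound 1 to compound 3 (within the scatter) stays within the scatter. No measurement is available that would explain these differences in the series.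

The compounds shown leave open whether the higher number of compound 4 follows the chlorine atoms or the pattern of substitution, a question that 3,4-difluorophenyl and 3,5-dichlorophenyl at this position would address. Also open, as far as these compounds go, is how this position responds to groups other than halogens, such as methyl, methoxy or trifluoromethyl on the phenyl group.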